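The source may hold more compounds than are shown below. What is called first, only, known or untested is meant among the compounds shown, and "the series" means these compounds.

Three compounds have been measured in a functional assay on MCF7 cells (Homo sapiens) for antiproliferative activity, read by MTT assay, with a stated time of 72 h; on this read-out lower numbers stand for stronger inhibition and higher numbers for weaker inhibition:

Compound 1, `COc1cc2ncnc(N3CCCc4ccccc43)c2cc1NC(=O)/C=C/CN1CCCC1`, gives 3190 nM.
Compound 2, `COc1cc2ncnc(N3CCCc4ccccc43)c2cc1NC(=O)/C=C/CN1CCCCC1`, gives 3930 nM.
Compound 3, `O=C(/C=C/CN1CCCC1)Nc1cc2c(N3CCCc4ccccc43)ncnc2cc1O[C@@H]1CCOC1`, gives 4250 nM.

Compound 2 differs from compound 1 by one change, (piperidin-1-yl in place of pyrrolidin-1-yl on a saturated chain carbon bound to a double-bonded chain carbon). In this assay this change made a step of a 1.2-fold higher number from compound 1 to compound 2 (0.09 log units; within the scatter), so the two compounds cannot be told apart on this read-out. Compound 3 differs from compound 1 at another place, (oxolan-3-yl in place of methyl on an oxygen on an aromatic ring), and here too the step is small, a 1.3-fold higher number from compound 1 to compound 3 (0.12 log units; within the scatter). Within the data shown here, compound 2 and compound 3 have no step between them worked out here; their two values lie close together.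

Compound 4, `O=C(/C=C/CN1CCCCC1)Nc1cc2c(N3CCCc4ccccc43)ncnc2cc1O[C@@H]1CCOC1`, is not yet measured. It differs from compound 3 by piperidin-1-yl in place of pyrrolidin-1-yl on a saturated chain carbon bound to a double-bonded chain carbon. Among the measured compounds shown here, this is the same change as the one from compound 1 to compound 2, made here on the core of compound 3, and the surroundings of the place are described in the same words in both cases. For the measured compounds named here, since that earlier change gave a 1.2-fold higher number from compound 1 to compound 2 (0.09 log units; within the scatter), the step from compound 3 to compound 4 in this assay is expected to be of about the same size, a 1.2-fold higher number from compound 3 to compound 4 (0.08 log units; within the scatter), with wide uncertainty because only one example of the change is known. For compound 4 the estimate is 5100 nM, expected to fall between 2500 nM and 10500 nM.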

Compound 4, half-maximal inhibitory concentration: 4450 nM
Compound 4: middle estimate off by 1.1-fold (0.06 log units), on the high side, and the stated range covers the measured number.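

In this assay, piperidin-1-yl in place of pyrrolidin-1-yl on the core bearing oxolan-3-yl gave a 1.0-fold higher number from compound 3 to compound 4 (0.02 log units; within the scatter), and this step matches the one seen earlier for the same change on the other core: the same change on two cores in this assay, a 1.2-fold higher number (0.09 log units; within the scatter) from compound 1 to compound 2 and a 1.0-fold higher number (0.02 log units; within the scatter) from compound 3 to compound 4, 1.2-fold (0.07 log units) apart, within the scatter of two such steps. Read the other way round, oxolan-3-yl in place of methyl on the oxygen gave a 1.1-fold higher number from compound 2 to compound 4 (0.05 log units; within the scatter), and this change also behaved alike on both cores: the same change on two cores in this assay, a 1.3-fold higher number (0.12 log units; within the scatter) from compound 1 to compound 3 and a 1.1-fold higher number (0.05 log units; within the scatter) from compound 2 to compound 4, 1.2-fold (0.07 log units) apart, within the scatter of two such steps. Together the four compounds show that, in this small set, neither change separates its pair on either core, but each comparison rests on just two steps, all within the scatter, so they do not show that a step large enough to read would carry from one core to another.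

The compounds shown leave open whether a different amine on the saturated chain carbon, such as morpholin-4-yl or dimethylamino, would give a step beyond the scatter. They also leave open whether another group on the oxygen on the aromatic ring, such as a longer chain like 2-methoxyethyl, would do so, and whether any such step would hold on both cores.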